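Swapping the aryl group on a shared core

The compounds below may be only part of what the source reports. "The series", "measured", "known", "first", "only" and "open" are said of these compounds alone.

Among the compounds with values here, compound 2 `Clc1ccc(-c2cn3ccnc3c(-c3ccc4ncn(C5CCCCC5)c4c3)n2)cc1` gives 36.1% in a functional assay on UO-31 cells (Homo sapiens) for inhibition, read by sulforhodamine B assay, with a stated time of 48 h, tested at 10 uM (on this read-out higher numbers stand for more inhibition at the one concentration tested (going by the name of the read-out) and lower numbers for less inhibition), the higher of the two numbers measured so far; compound 1 `c1ccc2c(-c3cn4ccnc4c(-c4ccc5ncn(C6CCCCC6)c5c4)n3)cccc2c1` gives 23% in this assay. Within the data shown here, the only measured step, a number 13.1 percentage points higher from compound 1 to compound 2 (beyond the scatter), replaced the aryl group at the same place as the change now considered. Compound 3 `FC(F)(F)c1cccc(-c2cn3ccnc3c(-c3ccc4ncn(C5CCCCC5)c4c3)n2)c1` differs from compound 2 by 3-(trifluoromethyl)phenyl in place of 4-chlorophenyl on an aromatic carbon. That earlier step shows a modest move is possible, but one pair cannot fix the direction for a new aryl group, so the expected step of a number 6.1 percentage points lower from compound 2 to compound 3 (within the scatter) is small and of uncertain sign. Compound 3 is therefore estimated at 30%, between 10% and 52%.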

Compound 3, a percentage reported as inhibition, at one concentration (the size of the read-out at that concentration, not a potency): 22.5%
Beside the measured number, compound 3's estimate is 7.5 percentage points above it; measured number inside the range.
By their numbers in this assay, from the lowest: compounds 3 and 1 (each within the scatter of the next); then compound 2.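

At this position in this assay the step of a number 13.6 percentage points lower from compound 2 to compound 3 (beyond the scatter) cancels the earlier gain, and the step of a number 0.5 percentage points lower from compound 1 to compound 3 (within the scatter) leaves the 3-(trifluoromethyl)phenyl and naphthalen-1-yl groups level. Among these three aryl groups, only 4-chlorophenyl stands apart. Nothing measured here explains this difference.

The two phenyl groups differ in both their substituent and its place on the ring, and these compounds do not separate the two changes. From the compounds shown here alone, whether an amine or a carboxylic acid on that phenyl ring would change the number also remains open.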